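The compounds below may be only part of what the source reports. "The series", "measured", "known", "first", "only" and "open" are said of these compounds alone.

Measured so far:
compound 1, `COc1ccc(CS/C=C\C[S+]([O-])Cc2ccc(OC)cc2)cc1`: > 200000 nM
compound 2, `C=CCSS/C=C\C[S+]([O-])CCCO`: 38000 nM

Both compounds were tested in a functional assay on WHCO1 cells (Homo sapiens) for antiproliferative activity, read by MTT assay, with a stated time of 48 h; a lower number here means a stronger inhibitor, a higher number a weaker inhibitor. The value for compound 1 is a limit of the assay rather than a number: in this assay compound 1 gives > 200000 nM. Compound 2, built on a different chain, gives 38000 nM in this assay. Where compound 1 stands is therefore known only as a boundary: the limit of > 200000 nM in this assay, at which 1 of the 2 values shown sits. Since compounds 1 and 2 differ in more than one place, their two values are set side by side here without drawing a step between them.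

The compound of interest is compound 3, `COc1ccc(CS/C=C/C[S+]([O-])Cc2ccc(OC)cc2)cc1`. Compared with compound 1 it changes in a single way: the two compounds have the same atoms and bonds; at least one stereo element is drawn with a configuration in one of them and without one in the other: 1 of 2 stereo elements differ; a double bond is drawn Z in compound 1 and E in compound 3. Going by the values given here, with compound 1 sitting only at a limit, and no measured pair showing what such a change does here, there is little ground for expecting a large move in either direction; the step from compound 1 to compound 3 is expected to be a number no higher from compound 1 to compound 3 (the limit leaves the size open), which is no more than the usual scatter. Compound 3 is accordingly estimated at 200000 nM, within a range of 60000 nM to 600000 nM.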

Compound 3, half-maximal inhibitory concentration: > 200000 nM
Compound 3: a limit, no number; the forecaster's own chance of this, stated with the estimate: 70%; the middle value lies on the limit itself.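

In this assay compound 3 gives > 200000 nM, which is a limit and not a number. Compound 1 also sits at a limit, so no step can be read between compound 1 and compound 3: the limit of > 200000 nM in this assay, at which 2 of the 3 values shown sit.

The compounds shown leave open whether drawing this double bond Z or E changes the activity in this assay at all.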